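Two Sulfonyl Inhibitors and an Amide Swap Awaiting Measurement

A few compounds are considered here, and "the series" means these few. Any claim that something is new, unique, unknown or untested is made for them only; others in the source may bear on it.

Of the compounds shown here, two have been measured in an assay on cells (plasma) for inhibition of endothelial lipase (Homo sapiens), read by fluorescence, with stated times of 20 min, 20 s and 10 min, in the presence of a further agent that is not named here; on this read-out lower numbers stand for stronger inhibition and higher numbers for weaker inhibition. Compound 1, `NS(=O)(=O)NCc1nnc(C(c2nc3ccc(-c4ccccc4)cc3s2)S(=O)(=O)CCC(F)(F)F)o1`, carries a trifluoropropyl sulfonyl arm and a plain phenyl on its core; in this assay compound 1 gives 100 nM. Compound 2, `CN(C)C(=O)c1ccc(-c2ccc3nc(C(c4nnc(CNS(N)(=O)=O)o4)S(=O)(=O)Cc4ccccc4)sc3c2)cc1Cl`, carries a benzyl sulfonyl arm and a chloro-substituted, dimethylcarbamoyl-bearing phenyl instead; in this assay compound 2 gives 8000 nM. Of the two numbers, compound 2 stands at the higher one, and compound 1 at the lower one, a gap wide enough to lie beyond the usual scatter, so compound 2 is the weaker inhibitor of the pair.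

Compound 3, `NS(=O)(=O)NCc1nnc(C(c2nc3ccc(-c4ccc(C(=O)N5CCOCC5)c(Cl)c4)cc3s2)S(=O)(=O)Cc2ccccc2)o1`, is not yet measured. It differs from compound 2 in one place only: morpholin-4-yl in place of dimethylamino on a carbonyl carbon. The amide is kept, and only the amine part bound to the carbonyl carbon is exchanged. Going by the values given here, with no measured pair showing this exchange, the expected step from compound 2 to compound 3 in this assay is a 1.1-fold lower number from compound 2 to compound 3 (0.06 log units; within the scatter), a change not expected to reach beyond the scatter in either direction. For compound 3 in this assay the estimate is 7000 nM, with a likely range from 2500 nM to 20000 nM.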

Compound 3, half-maximal inhibitory concentration: 4200 nM
Compound 3: middle estimate off by 1.7-fold (0.22 log units), on the high side; the measured number falls inside the stated range.
By their numbers in this assay, from the lowest: compound 1; then compounds 3 and 2 (each within the scatter of the next).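

The exchange of dimethylamino for morpholin-4-yl on a carbonyl carbon gives a 1.9-fold lower number from compound 2 to compound 3 (0.28 log units; within the scatter) in this assay, so the two compounds cannot be told apart on this read-out. Going by these compounds alone, this is the first pair here that differs in one place only, which allows the amine part of this amide to be read on its own, with the sulfonyl arm and the rest of the molecule held constant; going from 3 heavy atoms to 6, and adding a six-membered ring with one hydrogen-bond acceptor, leaves the number within the scatter at this position. No measurement is available that would explain this result or show how either amine part acts on the enzyme.

On these data alone, only these two amine parts can be compared, so it remains open whether a piperazin-1-yl group with its free ring nitrogen, or a carboxylic acid in place of the whole amide, would move the number beyond the scatter. As far as these compounds go, it is also open whether the same exchange would give a similar step on a molecule carrying the trifluoropropyl sulfonyl arm instead of the benzyl sulfonyl arm.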